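Chain extension on the amino side chain of the shared core

The compounds below may be only part of what the source reports. "The series", "measured", "known", "first", "only" and "open" are said of these compounds alone.

Measured compounds:
Compound 1 `CCCN(CC1CC1)c1cc(C)nc2c(-c3ccc(Cl)cc3Cl)nn(C)c12` gives 1.7 nM in an assay on HEK293 cells for displacement of a labelled ligand from corticotropin-releasing factor receptor 1 (Homo sapiens); on this read-out lower numbers stand for stronger inhibition and higher numbers for weaker inhibition.
Compound 2 `CCCCCN(CC1CC1)c1cc(C)nc2c(-c3ccc(Cl)cc3Cl)nn(C)c12` gives 1.5 nM in this assay.
Compound 3 `CCN(CCCOC)c1cc(C)nc2c(-c3ccc(Cl)cc3Cl)nn(C)c12` gives 12.5 nM in this assay.

The change ethyl in place of hydrogen on a saturated chain carbon, three bonds along the chain from a nitrogen on an aromatic ring produced a 1.1-fold lower number from compound 1 to compound 2 (0.05 log units; within the scatter). Compound 3 differs from compound 1 by ethyl(3-methoxypropyl)amino in place of (cyclopropylmethyl)(propyl)amino on an aromatic carbon, and that change produced a 7.4-fold higher number from compound 1 to compound 3 (0.87 log units; beyond the scatter). Compound 4 `CCCCN(CCCOC)c1cc(C)nc2c(-c3ccc(Cl)cc3Cl)nn(C)c12` is not yet measured; it differs from compound 3 by ethyl in place of hydrogen on a saturated chain carbon, two bonds along the chain from a nitrogen on an aromatic ring. This is the same kind of change as that from compound 1 to compound 2, though here the saturated chain carbon is two bonds along the chain from a nitrogen on an aromatic ring rather than three bonds. Because a 1.1-fold lower number from compound 1 to compound 2 (0.05 log units; within the scatter) lay within the scatter, the step of a 1.3-fold lower number from compound 3 to compound 4 (0.10 log units; within the scatter) is expected to be small as well. On that basis compound 4 is estimated at 10 nM in this assay.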

Compound 4, inhibition constant: 18 nM
For compound 4 the middle estimate is 1.8-fold (0.26 log units) below the measured one; low and high end bracket the measured number.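

In this assay, ethyl in place of hydrogen on a saturated chain carbon gives a 1.4-fold higher number from compound 3 to compound 4 (0.16 log units; within the scatter) and so stays within the scatter on the second core too. The two cases compare as follows: the same change on two cores in this assay, a 1.1-fold lower number (0.05 log units; within the scatter) from compound 1 to compound 2 and a 1.4-fold higher number (0.16 log units; within the scatter) from compound 3 to compound 4, 1.6-fold (0.21 log units) apart, within the scatter of two such steps

The change therefore carries between these two cores without a difference that can be told from the scatter, though the carbon lies three bonds along the chain from the nitrogen in one case and two bonds in the other, but two pairs do not show that it holds on any other core.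

Open, going by these compounds, is whether a longer chain at this place would still leave the number unmoved. Also open, on these data alone, is how a terminal amine or carboxylic acid on the chain would read.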